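A chloro added to a well-tolerated compound

The source may report more compounds than this note shows. Statements on the series, on what has been measured and on what is new or still open speak of the compounds shown alone.

Measured in an ADME assay on HEK293 cells (Homo sapiens) for cytotoxicity, read by reporter gene assay and resazurin assay, with a stated time of 48 h; a lower number here means that less compound is tolerated, a higher number that more compound is tolerated:
- compound 1 `O=C(Nc1ccc(Sc2nc3ccccc3s2)cc1)c1ccccc1`: > 100000 nM
- compound 2 `COc1c(Br)cccc1C(=O)Nc1ccc(Sc2nc3ccccc3s2)cc1`: > 100000 nM

Compound 2 gives > 100000 nM, which is a limit of the assay and not a number. Both measured compounds sit at the same ceiling, (the limit of > 100000 nM in this assay, at which 2 of the 2 values shown sit). Among the compounds with values here, the only measured step is therefore a step that the two limits leave unreadable from compound 1 to compound 2, and it offers no size to carry forward.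

Compound 3 `COc1c(Br)cccc1C(=O)Nc1ccc(Sc2nc3ccccc3s2)c(Cl)c1` differs from compound 2 in one place: chloro in place of hydrogen on an aromatic carbon. In words, this is chloro in place of hydrogen on an aromatic carbon. Within the data shown here, the measured step concerns a group on a carbonyl carbon, not this change, and no measured pair involves chloro. The expectation therefore rests on one observation: neither of the two compounds has yet given a number in this assay. No step beyond the usual scatter is expected, and another limit is the likeliest result. Any number that does appear would have to lie on the less tolerated side of that limit.

The expected change is a number no higher from compound 2 to compound 3 (the limit leaves the size open). The estimate for compound 3 is 100000 nM, with an expected range from 40000 nM to 200000 nM.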

Compound 3, half-maximal cytotoxic concentration: > 100000 nM
Compound 3: no number, only a limit (the forecaster's own chance of this, stated with the estimate: 70%); the middle value lies on the limit itself.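

In this assay compound 3 gives > 100000 nM, which is a limit of the assay and not a number, so the change from compound 2 to compound 3 cannot be read as a step. The compounds shown leave open whether the chloro alters tolerance at all, and at what concentration any of them would become cytotoxic, because all share one ceiling: the limit of > 100000 nM in this assay, at which 3 of the 3 values shown sit.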